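The source may hold more compounds than are shown below. What is called first, only, known or untested is meant among the compounds shown, and "the series" means these compounds.

Measured in a functional assay on ECa-109 cells for inhibition, with ECa-109 cell line (Homo sapiens) as the target, read by sulforhodamine B assay; a lower number here means a stronger inhibitor, a higher number a weaker inhibitor:
- Compound 1 `O=C1C(Nc2ccccc2F)=CC(=O)c2c1nc1n2[C@H]2OC[C@@H](O)[C@H]2OC1`: 2660 nM
- Compound 2 `Cc1ccc(NC2=CC(=O)c3c(nc4n3[C@H]3OC[C@@H](O)[C@H]3OC4)C2=O)cc1C`: 4090 nM
- Compound 3 `O=C1C(N2CCCCC2)=CC(=O)c2c1nc1n2[C@H]2OC[C@@H](O)[C@H]2OC1`: > 8000 nM (a limit, not a number)

Compound 3 has no exact value, only (the limit of > 8000 nM in this assay, at which 1 of the 3 values shown sits). Compound 4 `O=C1C(NC2CCCCC2)=CC(=O)c2c1nc1n2[C@H]2OC[C@@H](O)[C@H]2OC1` carries cyclohexylamino in place of piperidin-1-yl on a double-bonded ring carbon. Like compound 1 and compound 2, it has a ring attached through an amino group, although its ring is not aromatic. The relevant measured steps are an at least 3.0-fold higher number from compound 1 to compound 3 (0.47 log units; beyond the scatter) and an at least 1.9-fold higher number from compound 2 to compound 3 (0.29 log units; that floor lies within the scatter). Read in reverse, these suggest a modest move toward a lower number. The expected step is an at least 1.6-fold lower number from compound 3 to compound 4 (0.20 log units; that floor lies within the scatter). The estimated value for compound 4 is 5000 nM, with an expected range of 2200 nM to 8000 nM.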

Compound 4, half-maximal inhibitory concentration: > 16000 nM
Compound 4 gave a limit, no number (the forecaster's own chance of this, stated with the estimate: 30%); middle value at least 3.2-fold (0.50 log units) from the limit.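

Compound 4 gives > 16000 nM, a limit and not a number. With the amine nitrogen kept, cyclohexyl gives an at least 3.9-fold higher number from compound 2 to compound 4 (0.59 log units; beyond the scatter) and an at least 6.0-fold higher number from compound 1 to compound 4 (0.77 log units; beyond the scatter), so at this position the amino link alone does not preserve the activity seen with the two aromatic rings in these compounds. The step between compound 3 and compound 4 cannot be read, as both carry only limits.

On these data alone, it remains open whether an unsubstituted phenyl or a pyridine ring on the amine nitrogen would match compound 1 or compound 2.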